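Thiophene attachment point in a chlorofuran pyridine series

A few compounds are considered here, and "the series" means these few. Any claim that something is new, unique, unknown or untested is made for them only; others in the source may bear on it.

Two compounds of the series have numbers in an assay on isolated protein for inhibition of DNA topoisomerase 1 (Homo sapiens), tested at 100 uM; a lower number here means a weaker effect, a higher number a stronger effect of the compound at the concentration tested. Compound 1 `Clc1ccc(-c2cc(-c3ccsc3)nc(-c3ccco3)c2)o1` gives 8.2% in this assay. For the measured compounds named here, compound 2 `Clc1ccc(-c2cc(-c3ccc(Cl)o3)cc(-c3ccsc3)n2)cc1` gives 29.8% in this assay, the higher of the two numbers; the only measured step is a number 21.6 percentage points higher from compound 1 to compound 2 (beyond the scatter), which puts compound 2 above compound 1 beyond the scatter.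

Compound 3 `Clc1ccc(-c2cc(-c3ccc(Cl)o3)cc(-c3cccs3)n2)cc1` keeps the core of compound 2 and differs from it in one place: thiophen-2-yl in place of thiophen-3-yl on an aromatic carbon. Both compounds carry the 4-chlorophenyl group and the 5-chlorofuran-2-yl group on the same carbons of the core; only the point at which the thiophene ring is joined is moved.

Going by the values given here, no measured step in this assay concerns a change of the thiophene attachment; the single step from compound 1 to compound 2 swaps a furan-2-yl for a 4-chlorophenyl and says nothing about this move. The number for compound 3 is therefore expected to stay close to that of compound 2, with an estimated step of a number 0.2 percentage points higher from compound 2 to compound 3 (within the scatter) that lies within the scatter.

Compound 3 is estimated at 30% in this assay, within a range from 14% to 46%.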

Compound 3, a percentage reported as inhibition, at one concentration (the size of the read-out at that concentration, not a potency): 38.9%
Compound 3: the middle estimate sits 8.9 percentage points below what was measured, and the stated range covers the measured number.
By their numbers in this assay, from the lowest: compound 1; then compounds 2 and 3 (each within the scatter of the next).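

In this assay, thiophen-2-yl in place of thiophen-3-yl on the aromatic carbon next to the ring nitrogen gives a number 9.1 percentage points higher from compound 2 to compound 3 (within the scatter), so the two attachment points cannot be told apart at this position with the 4-chlorophenyl and 5-chlorofuran-2-yl groups held in place. This is the first reading at this position, and it contrasts with the change at the other place in the series, where a number 21.6 percentage points higher from compound 1 to compound 2 (beyond the scatter) stands as the only step beyond the scatter, so among the compounds shown, only the exchange of furan-2-yl for 4-chlorophenyl separates any pair. No independent data bear on why the two thiophene attachments read alike.

Going by these compounds, it remains open whether the same indifference to the thiophene attachment holds with furan-2-yl in place of 4-chlorophenyl, as in the core of compound 1, and whether a single-concentration read-out hides a difference in potency between the two isomers. On these data alone, it is also open how this position responds to a group other than a thiophene, such as an amine, a carboxylic acid or a longer alkyl chain.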